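The source may hold more compounds than are shown below. What is called first, only, known or untested is meant among the compounds shown, and "the series" means these compounds.

Only one of the first two compounds built on the shared core has a number. In a functional assay on L6 cells (Rattus norvegicus) for inhibition (on this read-out lower numbers stand for stronger inhibition and higher numbers for weaker inhibition), compound 1 `CC(C)c1c(C(=O)NCc2cccc(F)c2F)nn(-c2ccc(F)cc2)c1OC[C@@H](O)C[C@@H](O)CC(=O)O` gives 120 nM. Compound 2 `CC(C)c1c(C(=O)NCc2ccc(Cl)cc2)nn(-c2ccc(F)cc2)c1OC[C@@H](O)C[C@@H](O)CC(=O)O` cannot be placed on that scale: the entry for compound 2 reads "not determined" (no result reported), so it offers no starting value. Compound 3 `CC(C)c1c(C(=O)N(C)Cc2cccc(F)c2)nn(-c2ccc(F)cc2)c1OC[C@@H](O)C[C@@H](O)CC(=O)O` is still to be measured in this assay. The structural change from compound 2 is (3-fluorobenzyl)(methyl)amino in place of (4-chlorobenzyl)amino on a carbonyl carbon. On a carbonyl carbon, (4-chlorobenzyl)amino leaves and (3-fluorobenzyl)(methyl)amino enters, so the new group has no hydrogen-bond donor where the old one had its donor. Within the data shown here, no measured pair shows what such a change does, and without a value for compound 2 the step itself cannot be sized. Among the measured compounds shown here, the only reference is compound 1 at 120 nM, which makes any forecast loose. A moderate move towards weaker inhibition than that reference is expected, though a result within the usual scatter of it would not surprise. For compound 3 the estimated value is 300 nM, with an expected range from 70 nM to 1300 nM.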

Compound 3, half-maximal inhibitory concentration: 2470 nM
The estimate for compound 3 lay 8.2-fold (0.92 log units) below the measured number, and the stated range ends below it.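

In this assay, the change on this carbonyl carbon can be sized only by a 21-fold higher number from compound 1 to compound 3 (1.31 log units; beyond the scatter), where (3-fluorobenzyl)(methyl)amino stands in place of (2,3-difluorobenzyl)amino; compound 2 carries no number, so the step from it to compound 3 cannot be read. Among these compounds, this large step is the first measured sign that inhibition depends on the group at this position, which a single value from compound 1 could not show. The change removes the amide hydrogen and also alters the fluorines on the benzyl ring, so the step cannot be assigned to either alteration alone, and no measurement available here explains its size.

On these data alone, what remains open is how much of the step belongs to the methyl group on the nitrogen and how much to the fluorine pattern, a question that (3-fluorobenzyl)amino or (2,3-difluorobenzyl)(methyl)amino on the same carbonyl carbon would address. The compounds shown also leave open how a longer chain, such as (2-phenylethyl)amino, would fare at this position.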